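Notes on the ureido analogue of compound 2

The compounds below may be only part of what the source reports. "The series", "measured", "known", "first", "only" and "open" are said of these compounds alone.

Compound 1 `O=S(=O)(c1cccc(F)c1)c1ccc2c(c1)CCC[C@H]2CN1CC(O)C1` and compound 2 `CN(CC(N)=O)C[C@@H]1CCCc2cc(S(=O)(=O)c3cccc(F)c3)ccc21` share one core and differ only at the substituent on the saturated chain carbon bound to a saturated ring carbon. In an assay on isolated protein for displacement of a labelled ligand from 5-hydroxytryptamine receptor 6 (Homo sapiens) (a lower number here means a stronger inhibitor, a higher number a weaker inhibitor), compound 1 gives 0.1 nM, and in the same assay compound 2 gives 1.26 nM. Going by the values given here, the step of a 13-fold higher number from compound 1 to compound 2 (1.10 log units; beyond the scatter) is the only measured step so far. Among the two numbers in this assay compound 2 stands highest, with compound 1 as its only and nearest neighbour.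

Compound 3 `NC(=O)NC[C@@H]1CCCc2cc(S(=O)(=O)c3cccc(F)c3)ccc21` takes the next change from compound 2: ureido in place of (carbamoylmethyl)(methyl)amino on a saturated chain carbon bound to a saturated ring carbon. Among the compounds with values here, no measured pair covers this exchange directly; the one step in hand, a 13-fold higher number from compound 1 to compound 2 (1.10 log units; beyond the scatter), shows that the substituent at this position shifts the number by a large amount, so a sizeable shift is expected here as well rather than none beyond the scatter, and in the direction of a higher number. Compound 3 is therefore expected to give about 10 nM in this assay, within a range from 2 nM to 60 nM, which means an expected step of a 7.9-fold higher number from compound 2 to compound 3 (0.90 log units; beyond the scatter).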

Compound 3, inhibition constant: 0.2 nM
Estimate against measurement, compound 3: 50-fold (1.70 log units) above; the whole stated range lies above it.
By their numbers in this assay, from the lowest: compounds 1 and 3 (each within the scatter of the next); then compound 2.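

Compound 3 shows that the substituent on the saturated chain carbon bound to a saturated ring carbon need not contain a ring to give a low number in this assay: ureido, which has no ring, in place of 3-hydroxyazetidin-1-yl gives a 2.0-fold higher number from compound 1 to compound 3 (0.30 log units; within the scatter). The earlier step, a 13-fold higher number from compound 1 to compound 2 (1.10 log units; beyond the scatter), therefore cannot be read as a general cost of exchanging 3-hydroxyazetidin-1-yl for an open chain, since among these three compounds only compound 2 stands apart from the others. Ureido in place of (carbamoylmethyl)(methyl)amino gives a 6.3-fold lower number from compound 2 to compound 3 (0.80 log units; beyond the scatter), so two open groups at this position, both with a carbonyl, are separated by a step beyond the scatter, and the exchange changes the heavy-atom count and the donor and acceptor counts together. No measurement in hand gives a reason for these steps.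

The compounds shown leave open which part of the exchange from (carbamoylmethyl)(methyl)amino to ureido carries the step, as each of those counts changes within a single pair. On these data alone, an acetamido group or a methylated ureido at the same place would separate these parts, and how either would stand against compound 1 and compound 3 is still unknown.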